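Lengthening the hexyl chain of compound 3

The source may hold more compounds than are shown below. What is called first, only, known or untested is meant among the compounds shown, and "the series" means these compounds.

In a functional assay on brain (Rattus norvegicus, strain Wistar) for inhibition (on this read-out lower numbers stand for stronger inhibition and higher numbers for weaker inhibition), compound 1 (`CCCCCc1ccc(-c2c(C)[nH]c(=O)n2C2CCCCC2)cc1`) gives 10600 nM, compound 2 (`Cc1[nH]c(=O)n(C2CCCCC2)c1-c1ccc(OCCC(C)C)cc1`) gives 7200 nM and compound 3 (`CCCCCCc1ccc(-c2c(C)[nH]c(=O)n2C2CCCCC2)cc1`) gives 13700 nM. Compound 3 therefore lies within the scatter of both other compounds. The next compound is compound 4 (`CCCCCCCCCCCCCCc1ccc(-c2c(C)[nH]c(=O)n2C2CCCCC2)cc1`), and the change to it is octyl in place of hydrogen on a saturated chain carbon, six bonds along the chain from an aromatic carbon. The same difference, cut one bond further out, reads methyl to nonyl.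

The closest measured chain change is a 1.3-fold higher number from compound 1 to compound 3 (0.11 log units; within the scatter), a methyl in place of hydrogen on the chain. Exchanging the whole group gives a 1.5-fold lower number from compound 1 to compound 2 (0.17 log units; within the scatter) and a 1.9-fold higher number from compound 2 to compound 3 (0.28 log units; within the scatter). All three steps stay within the scatter, but none adds anything close to an octyl, so the data offer no direction for so large an addition. In this assay no step beyond the scatter is expected, with low confidence. The estimated step is a 1.1-fold lower number from compound 3 to compound 4 (0.02 log units; within the scatter). For compound 4 the expected value is 13000 nM, with an estimated range of 3000 nM to 50000 nM.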

Compound 4, half-maximal inhibitory concentration: > 100000 nM
Compound 4: a limit, no number; the forecaster's own chance of this, stated with the estimate: 20%; middle value at least 7.6-fold (0.88 log units) from the limit.
By their numbers in this assay, from the lowest: compounds 2, 1 and 3 (each within the scatter of the next). At a limit, above all of these: compound 4.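

Compound 4 gives a limit and not a number in this assay: the limit of > 100000 nM in this assay, at which 1 of the 4 values shown sits.
Within the data shown here, this is the first change to move the read-out beyond the scatter, with an at least 7.2-fold higher number from compound 3 to compound 4 (0.86 log units; beyond the scatter) for the octyl and an at least 9.4-fold higher number from compound 1 to compound 4 (0.97 log units; beyond the scatter) for the nonyl counted from the shorter chain. Compounds 1 and 3 stay within the scatter of each other, so this chain position tolerates a small addition but not one of this size, where inhibition becomes weaker.

From the compounds shown here alone, how much weaker compound 4 is remains unknown, since the steps give only a lower bound. Also open, going by these compounds, is where between hexyl and the chain of compound 4 the weakening sets in, and whether a decyl chain, or a long chain ending in a carboxylic acid or an amine, would retain the inhibition of compound 3.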